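The source may report more compounds than this note shows. Statements on the series, on what has been measured and on what is new or still open speak of the compounds shown alone.

In a functional assay on HeLa cells (Homo sapiens) for antiproliferative activity, read by MTT assay, with a stated time of 48 h (on this read-out higher numbers stand for weaker inhibition and lower numbers for stronger inhibition), compound 1 `N#Cc1nc2c(-c3nc4ccccc4[nH]3)c(N)n(CCO)c2nc1C#N` gives > 50000 nM, which is a limit and not a number. Going by the values given here, compound 2 `CN(C)CCCn1c(N)c(-c2nc3ccccc3[nH]2)c2nc(C#N)c(C#N)nc21` gives 25900 nM, the only true number so far in this assay. Compound 3 `N#Cc1nc2c(-c3nc4ccccc4[nH]3)c(N)n(CCCN3CCCCC3)c2nc1C#N` carries piperidin-1-yl in place of dimethylamino on a saturated chain carbon, three bonds along the chain from an aromatic nitrogen. Among the compounds with values here, the one measured step, an at least 1.9-fold lower number from compound 1 to compound 2 (0.28 log units; that floor lies within the scatter), concerns a different exchange on the chain, so it offers only a weak guide. No change beyond the scatter is therefore expected in this assay, and the expected step is a 1.3-fold lower number from compound 2 to compound 3 (0.11 log units; within the scatter). For compound 3 the estimated value is 20000 nM, within an expected range of 8000 nM to 50000 nM.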

Compound 3, half-maximal inhibitory concentration: 6680 nM
For compound 3 the middle estimate is 3.0-fold (0.48 log units) above the measured one, outside the stated range (below it).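

In this assay, going by these compounds alone, piperidin-1-yl in place of dimethylamino on a saturated chain carbon, three bonds along the chain from an aromatic nitrogen, gives a 3.9-fold lower number from compound 2 to compound 3 (0.59 log units; beyond the scatter) and is the first step here to lie beyond the scatter. (Piperidin-1-yl)methyl in place of hydroxy gives an at least 7.4-fold lower number from compound 1 to compound 3 (0.87 log units; beyond the scatter) and clears the scatter, which the floor of the earlier step did not. From the compounds shown here alone, that step remains a floor, since compound 1 stands at a limit and not a number: the limit of > 50000 nM in this assay, at which 1 of the 3 values shown sits. Whether a pyrrolidine ring, a morpholine ring or a longer chain at this place would lower the number further stays open.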